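Working notes: changing the sulfonyl group of compound 3

This account rests on a few compounds, and the source may have more. Where it says the series, first, only, none or still open, it means among the compounds named here.

- compound 1 `Cc1ccc(-c2nn(-c3ccccc3)cc2-c2nc3ccccc3n2S(=O)(=O)c2ccccc2)cc1` gives 960 nM
- compound 2 `Cc1ccc(-c2nn(-c3ccccc3)cc2-c2nc3ccccc3n2S(=O)(=O)c2ccc(F)cc2)cc1` gives 5060 nM
- compound 3 `O=S(=O)(c1ccccc1)n1c(-c2cn(-c3ccccc3)nc2-c2ccc(F)cc2)nc2ccccc21` gives 720 nM

In a functional assay on HepG2 cells (Homo sapiens) for antiproliferative activity, read by MTT assay, with a stated time of 24 h (on this read-out lower numbers stand for stronger inhibition and higher numbers for weaker inhibition), compound 3 reads 720 nM and shares the low end of the three numbers with compound 1, while compound 2 lies clearly higher. The next compound, compound 4 `Cc1ccc(C)c(S(=O)(=O)n2c(-c3cn(-c4ccccc4)nc3-c3ccc(F)cc3)nc3ccccc32)c1`, differs from compound 3 by 2,5-dimethylphenyl in place of phenyl on a sulfonyl sulfur in the group on the sulfonyl sulfur.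

Within the data shown here, only one measured step alters that group. It places fluoro in place of hydrogen on an aromatic carbon and gives a 5.3-fold higher number from compound 1 to compound 2 (0.72 log units; beyond the scatter) as its result. The other step, a 1.3-fold lower number from compound 1 to compound 3 (0.12 log units; within the scatter) as measured, leaves the sulfonyl group untouched and says little here. Among the measured compounds shown here, no measured compound carries 2,5-dimethylphenyl, so one step is thin support. For the measured compounds named here, a modest move to a higher number is expected, resting on compound 2 and its a 5.3-fold higher number from compound 1 to compound 2 (0.72 log units; beyond the scatter) as the sole guide, with a 2.1-fold higher number from compound 3 to compound 4 (0.32 log units; beyond the scatter) as the estimated step. For compound 4 the estimate is 1500 nM with an expected range of 450 nM to 5500 nM in this assay for now.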

Compound 4, half-maximal inhibitory concentration: 410 nM
Compound 4: middle estimate off by 3.7-fold (0.56 log units), on the high side, and the stated range ends above it.
By their numbers in this assay, from the lowest: compounds 4, 3 and 1 (each within the scatter of the next, the first and the last beyond it); then compound 2.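

In this assay, the group on the sulfonyl sulfur tolerates a larger aryl ring than phenyl: 2,5-dimethylphenyl in place of phenyl gives a 1.8-fold lower number from compound 3 to compound 4 (0.24 log units; within the scatter), so the two compounds cannot be told apart. Substitution on this ring therefore does not raise the number in every case, and compound 2 remains the one example that goes against this, with a 5.3-fold higher number from compound 1 to compound 2 (0.72 log units; beyond the scatter), although that step was made on a core with a different group elsewhere. No measurement available here explains why fluoro and 2,5-dimethylphenyl read differently.

Still open, from the compounds shown here alone, is whether 2,5-dimethylphenyl would read the same on the core of compound 1, and whether fluoro on the sulfonyl ring would cost as much on the core of compound 3. Also open, going by these compounds, is how an amine or a carboxylic acid on this ring, or a plain alkyl chain in its place on the sulfonyl sulfur, would read.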